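Aryl ester series: chloro positional isomer on the benzoate

This account rests on a few compounds, and the source may have more. Where it says the series, first, only, none or still open, it means among the compounds named here.

Compound 1 `CC1=CC[C@H](C(C)C)c2cc(C)c(OC(=O)c3ccc([N+](=O)[O-])cc3)cc21` and compound 2 `CC1=CC[C@H](C(C)C)c2cc(C)c(OC(=O)c3ccc(Cl)cc3)cc21` share one core and differ only in the benzoate substituent. In a functional assay on PC-3 cells (Homo sapiens) for antiproliferative activity, read by sulforhodamine B assay, with a stated time of 48 h, tested at 50 uM (on this read-out lower numbers stand for less inhibition and higher numbers for more inhibition at the one concentration tested (going by the name of the read-out)), compound 1 gives 36.7% and compound 2 gives 34.1%; the step of a number 2.6 percentage points lower from compound 1 to compound 2 (within the scatter) lies within the scatter, so the two numbers are within the scatter of each other and neither ranks. Compound 3 `CC1=CC[C@H](C(C)C)c2cc(C)c(OC(=O)c3cccc(Cl)c3)cc21` follows: 3-chlorophenyl in place of 4-chlorophenyl on a carbonyl carbon. Among the measured compounds shown here, no measured step relocates a chlorine on the ring, so the single step to hand gives no direction; the expected step of a number 0.1 percentage points lower from compound 2 to compound 3 (within the scatter) is none beyond the scatter. Compound 3 is estimated at 34% in this assay, range 20% to 48%.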

Compound 3, a percentage reported as inhibition, at one concentration (the size of the read-out at that concentration, not a potency): 23.4%
Compound 3: the middle estimate sits 10.6 percentage points above what was measured; the range from low to high includes it.
By their numbers in this assay, from the lowest: compound 3; then compounds 2 and 1 (each within the scatter of the next).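

In this assay the place of the chlorine on the aryl ring matters, which the nitro-to-chloro exchange could not show: 3-chlorophenyl in place of 4-chlorophenyl gives a number 10.7 percentage points lower from compound 2 to compound 3 (beyond the scatter). Against the 4-nitrophenyl ester the reading is a number 13.3 percentage points lower from compound 1 to compound 3 (beyond the scatter), which leaves compound 3 the lowest of the three. Nothing available explains this drop.

Still open, as far as these compounds go, is whether the drop belongs to chlorine alone or would recur with another group there, such as an amine or a carboxylic acid. With so few compounds, the pattern rests on this single chlorine pair.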